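A few compounds are considered here, and "the series" means these few. Any claim that something is new, unique, unknown or untested is made for them only; others in the source may bear on it.

Measured in an assay on HeLa cells for displacement of a labelled ligand from adenosine receptor A3 (Homo sapiens), with a stated time of 180 min, tested at 1 uM; a higher number here means more inhibition at the concentration tested (going by the name of the read-out), a lower number less inhibition:
compound 1 `CC1=C(C(=O)OC(C)C)C(C2CCCC2)N/C(=N/C#N)N1` gives 3%
compound 2 `CC1=C(C(=O)OC(C)C)C(c2ccsc2)N/C(=N/C#N)N1` gives 13%
compound 3 `CCOC(=O)C1=C(C)N/C(=N\C#N)NC1c1ccccc1` gives 13%

Compound 3 is level with compound 2 at the digits reported, and the two share the highest reading of the three; compound 1 lies furthest from compound 3, yet that gap is still within the usual scatter, so no order among the three can be claimed. Compound 4 `CC1=C(C(=O)OC(C)C)C(c2ccccc2)N/C(=N/C#N)N1` differs from compound 3 in one place: methyl in place of hydrogen on a saturated chain carbon bound to an oxygen next to a carbonyl group and a saturated chain carbon. Among the measured compounds shown here, the only step measured so far, a number 10 percentage points higher from compound 1 to compound 2 (within the scatter), concerns the substituent on the saturated ring carbon, not the ester, so no measured step speaks directly to an ethyl-to-isopropyl exchange. Compounds 1, 2 and 4 all carry the isopropyl ester and compound 1 and compound 2 sit close to compound 3, which gives no sign that the ester alone moves the read-out. Compound 4 is therefore expected to show no change at the digits printed from compound 3 to compound 4 (within the scatter), nothing beyond the scatter. Compound 4 is estimated at 13%, between 0% and 30%.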

Compound 4, a percentage reported as inhibition, at one concentration (the size of the read-out at that concentration, not a potency): 6%
Compound 4: middle estimate off by 7 percentage points, on the high side; low and high end bracket the measured number.
By their numbers in this assay, from the lowest: compounds 1, 4, 2 and 3 (each within the scatter of the next).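

In this assay, among the compounds shown here, the exchange of ethyl for isopropyl in the ester gives a number 7 percentage points lower from compound 3 to compound 4 (within the scatter) and is the first measured step at this position, which shows no change beyond the scatter with phenyl on the saturated ring carbon. With the isopropyl ester held fixed, phenyl can now be set against the other two groups on that carbon, giving a number 7 percentage points lower from compound 2 to compound 4 (within the scatter) and a number 3 percentage points higher from compound 1 to compound 4 (within the scatter), so neither exchange separates from the scatter either. No measurement at hand offers an explanation for these readings.

Going by these compounds, whether a longer chain or a carboxylic acid in place of the ester, or an amine on the saturated ring carbon, would move the reading beyond the scatter stays open. Also open, on these data alone, is whether the ethyl-to-isopropyl exchange would read the same with thiophen-3-yl or cyclopentyl on that carbon.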